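Shortening the Amide Chain of Compound 2

The source may report more compounds than this note shows. Statements on the series, on what has been measured and on what is new or still open speak of the compounds shown alone.

Of the compounds shown here, three sharing one core have been measured in a functional assay on the whole organism (Tail, strain ICR) with Mus musculus as the target, in the tail flick test, with a stated time of 90 min, at a dose of 25 umol/kg by the oral route; a lower number here means a weaker effect, a higher number a stronger effect of the compound at the dose given. Compound 1 `O=C(CN(c1nc(Cl)nc2[nH]cnc12)C1CC1)N[C@@H](CO)C(=O)OCc1ccccc1` gives 34.5%, and compound 3 `O=C(OCc1ccccc1)[C@@H]1CCCN1C(=O)CN(c1nc(Cl)nc2[nH]cnc12)C1CC1` gives 43.3%. Compound 2 `NC(=O)CC[C@H](NC(=O)CN(c1ncnc2c1ncn2C1CCCCO1)C1CC1)C(=O)OCc1ccccc1` gives 37.8% in this assay, the second highest of the three numbers; compound 1, the nearest, and compound 3, the furthest, both lie within the scatter of it, so no ranking among the three can be claimed.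

Compound 4 `NC(=O)C[C@H](NC(=O)CN(c1ncnc2c1ncn2C1CCCCO1)C1CC1)C(=O)OCc1ccccc1` has not yet been measured. It differs from compound 2 in one place: carbamoyl in place of carbamoylmethyl on a saturated chain carbon, two bonds along the chain from an amide-type nitrogen and a carbonyl carbon. Going by the values given here, no pair of measured compounds differing in a single place exists here, so the size of such a step in this assay is unknown from these data. Since all three measured values fall within the scatter of one another, nothing here supports a shift beyond the scatter in either direction. The step from compound 2 to compound 4 is therefore expected to be a number 0.8 percentage points lower from compound 2 to compound 4 (within the scatter). Compound 4 is estimated to give 37% in this assay, within a range from 26% to 48%.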

Compound 4, a percentage reported as activity, at one dose (the size of the read-out at that dose, not a potency): 35%
The estimate for compound 4 lay 2 percentage points above the measured number, within the range that was stated.
By their numbers in this assay, from the lowest: compounds 1, 4, 2 and 3 (each within the scatter of the next).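

In this assay, going by these compounds alone, the pair of compound 2 and compound 4 gives the first step that can be read at a single place: a number 2.8 percentage points lower from compound 2 to compound 4 (within the scatter) for carbamoyl in place of carbamoylmethyl. At this saturated chain carbon, then, the change from 2-carbamoylethyl to carbamoylmethyl leaves the read-out at the dose given within the usual scatter, so this one step shows no dependence on that difference in the chain. Nothing available gives a reason for the size of this step.

As far as these compounds go, what an amine, a carboxylic acid or a longer chain at this carbon would do in this assay stays open. So does whether the same change would give a similar step at another dose, since a read-out at one dose is not a potency.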